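A few compounds are considered here, and "the series" means these few. Any claim that something is new, unique, unknown or untested is made for them only; others in the source may bear on it.

Series notes, Thromboxane-A synthase, two compounds measured and one still open.

Compound 1 `C=C(C)C(CCC/C=C(\c1ccccc1)c1cccnc1)C(=O)O` stands lowest of the two numbers in hand: in an assay (Equus caballus) for inhibition of Thromboxane-A synthase (Homo sapiens), using microsomes (a lower number here means a stronger inhibitor, a higher number a weaker inhibitor), compound 1 gives 28 nM. The nearest is compound 2 `Cc1ccc(/C(=C/CCCCC(=O)O)c2cccnc2)cc1`, which in this assay gives 85 nM, a gap beyond the scatter, so compound 1 is the stronger inhibitor of the pair on these two numbers.

The open compound is compound 3 `C=CCC(CCC/C=C(\c1ccccc1)c1cccnc1)C(=O)O`. Its difference from compound 1 is counted as allyl in place of 1-methylethenyl on a saturated chain carbon bound to a carbonyl carbon and a saturated chain carbon. The two share every atom and differ only in how the three-carbon group on that chain carbon is joined. For the measured compounds named here, no step between measured compounds is available as a guide for this kind of change.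

The expectation for compound 3 is a step of a 1.4-fold higher number from compound 1 to compound 3 (0.15 log units; within the scatter), that is, a value within or barely beyond the scatter around compound 1, with a slight lean towards a weaker inhibitor. The estimate for compound 3 is 40 nM, expected to fall between 14 nM and 120 nM.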

Compound 3, half-maximal inhibitory concentration: 50 nM
The estimate for compound 3 lay 1.3-fold (0.10 log units) below the measured number; the measured number falls inside the stated range.
By their numbers in this assay, from the lowest: compounds 1, 3 and 2 (each within the scatter of the next, the first and the last beyond it).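

In this assay, allyl in place of 1-methylethenyl on the saturated chain carbon bound to a carbonyl carbon and a saturated chain carbon gives the first step readable at this position (a 1.8-fold higher number from compound 1 to compound 3 (0.25 log units; within the scatter)). On this one pair, joining the same three carbons differently leaves compound 1 and compound 3 within the scatter of each other, so the two groups cannot be told apart here. Nothing measured bears on a cause for this step.

Open, from the compounds shown here alone, is how a saturated propyl group, a longer chain such as pent-4-enyl, or an amine on the same chain carbon would read in this assay. Also open, going by these compounds, is whether a phenyl ring as in the shared core can carry a methyl group without a change in the number when the rest of the structure stays fixed.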